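This account rests on a few compounds, and the source may have more. Where it says the series, first, only, none or still open, it means among the compounds named here.

Measured so far in a functional assay on A2780 cells (Homo sapiens) for antiproliferative activity, read by sulforhodamine B assay, with a stated time of 72 h (a lower number here means a stronger inhibitor, a higher number a weaker inhibitor), are three compounds:
Compound 1 (`C[C@@H]1COC[C@@H](C)N1S(=O)(=O)c1ccc(NC(=O)NCc2cccnc2)cc1`) gives 745 nM
Compound 2 (`O=C(NCc1cccnc1)Nc1ccc(S(=O)(=O)N2CCCNCC2)cc1`) gives 594 nM
Compound 3 (`CC1CCN(S(=O)(=O)c2ccc(NC(=O)NCc3cccnc3)cc2)CCN1`) gives 109 nM

Compound 3 has the lowest number of the three, and its gaps to the other two lie beyond the scatter. Compound 4 (`N[C@H]1CC[C@H](NS(=O)(=O)c2ccc(NC(=O)NCc3cccnc3)cc2)CC1`) has the same atoms as compound 3, joined differently (a group of 8 heavy atoms (6 carbon, 2 nitrogen; one six-membered non-aromatic ring of carbon only) in place of a group of 8 heavy atoms (6 carbon, 2 nitrogen; one seven-membered non-aromatic ring with 2 hetero atoms), on a sulfonyl sulfur). On a sulfonyl sulfur, (4-aminocyclohexyl)amino, with its six-membered non-aromatic ring of carbon only, replaces a seven-membered non-aromatic ring with 2 hetero atoms.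

Among the compounds with values here, three measured steps bear on this. Changes to the group on that sulfur gave a 6.8-fold lower number from compound 1 to compound 3 (0.83 log units; beyond the scatter) and a 5.4-fold lower number from compound 2 to compound 3 (0.74 log units; beyond the scatter) while a 1.3-fold lower number from compound 1 to compound 2 (0.10 log units; within the scatter) stayed small. The second of these needed only methyl in place of hydrogen on a saturated ring carbon, so a small edit here can matter. Within the data shown here, no measured compound carries a ring of carbon only, so the uncertainty is wide. Compound 3 stands at 109 nM with both other groups giving higher numbers, so a modest rise is expected in this assay rather than a further fall. The expected change is a 2.6-fold higher number from compound 3 to compound 4 (0.41 log units; beyond the scatter) as an estimate only. For compound 4 the estimated value is 280 nM within an expected range from 70 nM to 1100 nM in this assay.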

Compound 4, half-maximal inhibitory concentration: 52 nM
For compound 4 the middle estimate is 5.4-fold (0.73 log units) above the measured one, and the stated range ends above it.
By their numbers in this assay, from the lowest: compound 4; then compound 3; then compounds 2 and 1 (each within the scatter of the next).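

In this assay, the group on the sulfonyl sulfur can hold a six-membered non-aromatic ring of carbon only and still improve on the best of the earlier groups: (4-aminocyclohexyl)amino gives a 2.1-fold lower number from compound 3 to compound 4 (0.32 log units; beyond the scatter), which leaves compound 4 with the lowest number of the four. Within the data shown here, the same group also produces the first large steps at this position, with an 11-fold lower number from compound 2 to compound 4 (1.06 log units; beyond the scatter) and a 14-fold lower number from compound 1 to compound 4 (1.16 log units; beyond the scatter), whereas every earlier step on this sulfur was modest or within the scatter. So changing the ring and how the atoms are joined, with the atom types and the heavy-atom count of the group unchanged from compound 3, still moves the number, but nothing measured alongside these values accounts for the change.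

The compounds shown leave open whether the amine on the cyclohexyl ring is needed, since no compound carries a hydroxyl, a carboxylic acid or a plain hydrogen at that place on the ring. They also leave open how much the two defined stereocentres matter, since (4-aminocyclohexyl)amino appears here in a single spatial arrangement.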